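Removing the benzyl ether aryl group from compound 1

A few compounds are considered here, and "the series" means these few. Any claim that something is new, unique, unknown or untested is made for them only; others in the source may bear on it.

Measured compounds:
compound 1 `COc1cc(OCc2cccc(O)c2)c2cc(-c3cn4nc(OC)sc4n3)oc2c1` gives 2700 nM
compound 2 `COc1cc(OCc2cccc(CCc3ccccc3)c2)c2cc(-c3cn4nc(OC)sc4n3)oc2c1` gives 1200 nM
compound 3 `COc1cc(OCc2cccc(Oc3ccccc3)c2)c2cc(-c3cn4nc(OC)sc4n3)oc2c1` gives 390 nM

These three compounds were tested in an assay on a cell-free system (plasma) for antagonist activity at proteinase-activated receptor 4 (Homo sapiens), with a stated time of 5 min, in the presence of a further agent that is not named here; on this read-out higher numbers stand for weaker inhibition and lower numbers for stronger inhibition. Compound 1 gives the highest number of the three in this assay; compound 2 is nearest to it, and compound 3 is furthest away, as the steps of a 2.3-fold lower number from compound 1 to compound 2 (0.35 log units; beyond the scatter) and a 6.9-fold lower number from compound 1 to compound 3 (0.84 log units; beyond the scatter) show. The step of a 3.1-fold lower number from compound 2 to compound 3 (0.49 log units; beyond the scatter) lies in the same direction.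

Compound 4 `COc1cc(OC)c2cc(-c3cn4nc(OC)sc4n3)oc2c1` differs from compound 1 by hydrogen in place of 3-hydroxyphenyl on a saturated chain carbon bound to an oxygen on an aromatic ring. Within the data shown here, none of the measured steps removes the aryl group itself; all three keep it and vary only what sits on it. Within that set, each exchange that put a larger group on the aryl gave a lower number, so the aryl group and what it carries appear to matter for this assay. Taking the whole 3-hydroxyphenyl away is a larger change than any measured step, and is expected to move the number in the opposite direction. Compound 4 is therefore expected to give a weaker result than compound 1, with a step of about a 3.0-fold higher number from compound 1 to compound 4 (0.47 log units; beyond the scatter), and an estimated value of 8000 nM in this assay, within a range from 2000 nM to 30000 nM.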

Compound 4, half-maximal inhibitory concentration: 530 nM
The estimate for compound 4 lay 15-fold (1.18 log units) above the measured number; the measured number lies below the stated range.
By their numbers in this assay, from the lowest: compounds 3 and 4 (each within the scatter of the next); then compound 2; then compound 1.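

In this assay, taking away the 3-hydroxyphenyl on the saturated chain carbon bound to an oxygen on an aromatic ring gives a 5.1-fold lower number from compound 1 to compound 4 (0.71 log units; beyond the scatter) and so turns (3-hydroxybenzyl)oxy into methoxy; the aryl group of compound 1 is therefore not required for inhibition in this series. The earlier compounds shown here all kept that aryl group and could not show this, and compound 4 goes against the impression they gave that a larger group brings a lower number: compound 3 gives 390 nM and compound 4 gives 530 nM as values within the scatter of each other, so the phenoxy-bearing benzyl ether and the plain methoxy cannot be told apart here. Nothing available here accounts for why removing the aryl group has this result.

The compounds shown leave open how the number responds to a longer chain such as ethoxy or propoxy in place of methoxy, or to an amine or a carboxylic acid on that saturated chain carbon. They also leave open where a plain benzyl ether, with hydrogen in place of the hydroxy on the aryl group, would fall.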